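Ethoxycarbonyl to isopropoxycarbonyl: half-life notes on the series

The source may report more compounds than this note shows. Statements on the series, on what has been measured and on what is new or still open speak of the compounds shown alone.

In an ADME assay on S9 fraction from intestine (Homo sapiens) for metabolic stability, read by LC-MS, with a stated time of 60 min, tested at 10 uM (on this read-out higher numbers stand for a longer-lived compound and lower numbers for a shorter-lived compound), compound 3 `CCOC(=O)[C@H](F)ON1C(=O)N2C[C@H]1C(C)=C[C@H]2C(N)=O` gives 0.115 h and compound 2 `CCCCCCOC(=O)[C@H](F)ON1C(=O)N2C[C@H]1C=C(C)[C@H]2C(=O)NCCS(N)(=O)=O` gives 0.095 h, two values within the scatter of each other. Compound 1 `CC1=C[C@@H]2CN(C(=O)N2O[C@H](F)C(=O)OC(C)OC(=O)OC(C)C)[C@@H]1C(N)=O` reads < 0.0167 h, which is a limit of the assay and not a number. Compound 4 `CC1=C[C@@H](C(N)=O)N2C[C@@H]1N(O[C@@H](F)C(=O)OC(C)C)C2=O` carries one change relative to compound 3: methyl in place of hydrogen on a saturated chain carbon bound to an oxygen next to a carbonyl group and a saturated chain carbon. This places methyl in place of hydrogen on a saturated chain carbon bound to an oxygen next to a carbonyl group and a saturated chain carbon, turning ethoxycarbonyl into isopropoxycarbonyl. Among the measured compounds shown here, no measured pair isolates this change. In this assay, a small upward move is expected, a 1.4-fold higher number from compound 3 to compound 4 (0.14 log units; within the scatter), not beyond the scatter. The estimate for compound 4 is 0.16 h, with an expected range of 0.06 h to 0.45 h.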

Compound 4, half-life: 0.6 h
For compound 4 the middle estimate is 3.8-fold (0.57 log units) below the measured one; the measured number lies above the stated range.
By their numbers in this assay, from the lowest: compounds 2 and 3 (each within the scatter of the next); then compound 4. At a limit, below all of these: compound 1.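

In this assay, among the compounds shown here, turning ethoxycarbonyl into isopropoxycarbonyl gives a 5.2-fold higher number from compound 3 to compound 4 (0.72 log units; beyond the scatter) and provides the first step that isolates one place. Methyl in place of hydrogen on this saturated chain carbon is therefore enough to move the half-life beyond the scatter, which the earlier compounds could not show. Nothing at hand bears on the cause of this step. Still open, going by these compounds, is whether a longer chain or a cyclopropyl group in place of the isopropyl would extend the half-life further. Also open, on these data alone, is whether the step holds when the primary amide carries a substituent.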